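The source may hold more compounds than are shown below. What is called first, only, known or untested is meant among the compounds shown, and "the series" means these compounds.

Compound 1 `O=C(CSC(=S)N[C@H]1CCOC1=O)Nc1cccc(Cl)c1`: 107000 nM
Compound 2 `O=C(CSC(=S)N[C@H]1CCOC1=O)Nc1ccccc1Cl`: a limit, not a number, > 128000 nM
Compound 3 `Cc1ccc(NC(=O)CSC(=S)N[C@H]2CCOC2=O)cc1`: 93900 nM

Three compounds share one core and differ only in the aryl group on the amide-type nitrogen. In a functional assay on EC9706 cells (Homo sapiens) for cytotoxicity, read by MTT assay, with a stated time of 72 h (a higher number here means a weaker inhibitor, a lower number a stronger inhibitor), compound 1 gives 107000 nM. For compound 2 the assay reports only a limit and no number, > 128000 nM. In this assay compound 3 gives 93900 nM, the lowest of the two numbers shown, but compound 1 lies within the scatter of it, a 1.1-fold lower number from compound 1 to compound 3 (0.06 log units; within the scatter). The other steps are also small: an at least 1.1-fold higher number from compound 1 to compound 2 (0.07 log units; that floor lies within the scatter) and an at least 1.3-fold lower number from compound 2 to compound 3 (0.13 log units; that floor lies within the scatter), neither beyond the scatter.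

Compound 4 `O=C(CSC(=S)N[C@H]1CCOC1=O)Nc1ccc(C(=O)/C=C/c2ccccc2)cc1` differs from compound 3 in one place: (2-phenylethenyl)carbonyl in place of methyl on an aromatic carbon. The measured steps all exchange a small substituent on the aryl group and none moved the number beyond the scatter; the present change introduces a far larger group than any of them, so they give no firm direction. On this basis compound 4 is expected to show a 2.1-fold lower number from compound 3 to compound 4 (0.32 log units; beyond the scatter), a modest shift toward a lower number at most. Compound 4 is estimated at 45000 nM, within a range from 10000 nM to 130000 nM.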

Compound 4, half-maximal inhibitory concentration: 44900 nM
Compound 4: the middle estimate sits 1.0-fold (0.00 log units) above what was measured; measured number inside the range.
By their numbers in this assay, from the lowest: compound 4; then compounds 3 and 1 (each within the scatter of the next). At a limit, above all of these: compound 2.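

The exchange of methyl for (2-phenylethenyl)carbonyl gives a 2.1-fold lower number from compound 3 to compound 4 (0.32 log units; beyond the scatter), and this is the only step among these compounds printed as beyond the scatter, though it is a modest one. It shows that in this assay a change on the aryl group of the amide-type nitrogen can move the number toward a stronger inhibitor, which the exchanges among the chlorophenyl and 4-methylphenyl groups did not show. Nothing among the data shown gives a reason for this step.

The compounds shown leave open which part of the entering group carries the shift: the carbonyl, the carbon-carbon double bond or the added phenyl ring. On these data alone, an acetyl group or a saturated 3-phenylpropanoyl group at the same aromatic carbon would separate these parts, and an amine or a carboxylic acid there remains unexplored in this account.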